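Dropping the Phenyl Group: Expected Loss of Cytotoxic Potency

The source may report more compounds than this note shows. Statements on the series, on what has been measured and on what is new or still open speak of the compounds shown alone.

Compound 1 `N#Cc1ccc(NC(=O)c2ccc(-c3ccccc3)cc2O)cc1` gives 700 nM in a functional assay on HL-60 cells (Homo sapiens) for cytotoxicity, read by luminescence and CellTiter-Glo, with a stated time of 3 days; on this read-out higher numbers stand for weaker inhibition and lower numbers for stronger inhibition.
Compound 2 `N#Cc1ccc(NC(=O)c2ccccc2O)cc1` gives 4620 nM in this assay.
Compound 3 `N#Cc1ccc(NC(=O)c2cc(Br)c(-c3ccccc3)cc2O)cc1` gives 700 nM in this assay.

For the measured compounds named here, the one change already measured is hydrogen in place of phenyl on an aromatic carbon, and it gave a 6.6-fold higher number from compound 1 to compound 2 (0.82 log units; beyond the scatter). The core of compound 3 differs from that of compound 1 by bromo in place of hydrogen on an aromatic carbon, a change that gave no change at the digits printed from compound 1 to compound 3 (within the scatter), so the bromo group on its own left the number where it stood.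

Compound 4 `N#Cc1ccc(NC(=O)c2cc(Br)ccc2O)cc1` is the unmeasured partner of compound 3. It differs by hydrogen in place of phenyl on an aromatic carbon. Going by the values given here, this is the same kind of change as that from compound 1 to compound 2, but the place is not identical: in compound 4 the entering hydrogen sits ortho to a bromo group, which has no counterpart in compound 2.

Because the bromo group changed nothing in no change at the digits printed from compound 1 to compound 3 (within the scatter), the step is expected to follow the earlier one, giving an estimated 6.6-fold higher number from compound 3 to compound 4 (0.82 log units; beyond the scatter) in this assay. Compound 4 is therefore expected to give about 4600 nM, with a likely range from 1500 nM to 14000 nM.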

Compound 4, half-maximal inhibitory concentration: 620 nM
For compound 4 the middle estimate is 7.4-fold (0.87 log units) above the measured one; measured number below the stated range.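

In this assay, hydrogen in place of phenyl gave a 1.1-fold lower number from compound 3 to compound 4 (0.05 log units; within the scatter), so the clear step seen on the core of compound 1 did not carry over to the bromo-bearing core: the same change on two cores in this assay, a 6.6-fold higher number (0.82 log units; beyond the scatter) from compound 1 to compound 2 and a 1.1-fold lower number (0.05 log units; within the scatter) from compound 3 to compound 4, 7.5-fold (0.87 log units) apart, beyond the scatter of two such steps. Read the other way, bromo in place of hydrogen gave a 7.5-fold lower number from compound 2 to compound 4 (0.87 log units; beyond the scatter), although the same change had made no difference on the phenyl-bearing core: the same change on two cores in this assay, no change at the digits printed (within the scatter) from compound 1 to compound 3 and a 7.5-fold lower number (0.87 log units; beyond the scatter) from compound 2 to compound 4, 7.5-fold (0.87 log units) apart, beyond the scatter of two such steps. Across these four compounds the two changes do not add up, so a step measured on one core did not predict the other, but the numbers do not show why, nor how far this holds beyond these compounds.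

The compounds shown leave open whether a chloro group, a methyl group or an amine in place of the bromo group would give the same result, and whether a cyclohexyl group or a pyridine ring would behave as the phenyl group does. Also open, as far as these compounds go, is whether the pattern holds if a carboxylic acid replaces the nitrile or a methoxy group replaces the hydroxy group.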